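A few compounds are considered here, and "the series" means these few. Any claim that something is new, unique, unknown or untested is made for them only; others in the source may bear on it.

Measured so far:
compound 1 `C[C@H](NC(=O)c1nnn(Cc2ccc(C(F)(F)F)cc2)c1C(F)(F)F)c1ccc(C(=O)O)cc1`
compound 2 `CCc1c(C(=O)N[C@@H](C)c2ccc(C(=O)O)cc2)nnn1Cc1ccc(C(F)(F)F)cc1`

In a functional assay on CHO cells for antagonist activity at prostaglandin E2 receptor EP4 subtype (Homo sapiens), read by calcium flux, with a stated time of 15 min (a higher number here means a weaker inhibitor, a lower number a stronger inhibitor), compound 1 gives > 10000 nM, which is a limit of the assay and not a number. Compound 2 gives > 10000 nM in this assay, likewise a limit. The step that the two limits leave unreadable from compound 1 to compound 2 is therefore unreadable. Compound 2 stands at the limit of > 10000 nM in this assay, at which 2 of the 2 values shown sit, with no number to rank it. Compound 3 `C[C@H](NC(=O)c1nnn(Cc2ccc(C(F)(F)F)cc2)c1-c1ccccc1)c1ccc(C(=O)O)cc1` differs from compound 2 by phenyl in place of ethyl on an aromatic carbon. Among the compounds with values here, no measured step bears on that change; the only one known cannot be read. For compound 3 the expected value is 15000 nM, with an estimated range from 3000 nM to 60000 nM. The step is expected to be a step that the limit leaves unreadable from compound 2 to compound 3, most likely again only a limit.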

Compound 3, half-maximal inhibitory concentration: > 10000 nM
Compound 3 was reported as a limit; the forecaster's own chance of this, stated with the estimate: 75%; the middle value is on the limit's open side.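

Compound 1, compound 2 and compound 3 all sit at a limit of the assay and not a number, so no new step among them can be read: the limit of > 10000 nM in this assay, at which 3 of the 3 values shown sit.

The compounds shown leave open whether trifluoromethyl, ethyl and phenyl differ at all at this aromatic carbon.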